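A Side-Group Exchange on a Shared Core

This account rests on a few compounds, and the source may have more. Where it says the series, first, only, none or still open, it means among the compounds named here.

Compound 1 `COC/C1=C/C[C@](C)(CCC=C(C)C)/C=C/[C@@H](OC(=O)C=C(C)C)[C@](C)(O)/C=C/C1=O`: 3070 nM
Compound 2 `CC(C)=CCC[C@]1(C)/C=C/[C@@H](OC(=O)C=C(C)C)[C@](C)(O)/C=C/C(=O)/C(C[Si](C)(C)C(C)(C)C)=C\C1`: 2770 nM
Compound 3 `COCOC/C1=C/C[C@](C)(CCC=C(C)C)/C=C/[C@@H](OC(=O)C=C(C)C)[C@](C)(O)/C=C/C1=O`: not yet measured

In a functional assay on HL-60 cells (Homo sapiens) for antiproliferative activity, read by MTT assay, with a stated time of 48 h (on this read-out higher numbers stand for weaker inhibition and lower numbers for stronger inhibition), compound 2 gives 2770 nM, level with compound 1 within the scatter. Compound 3 differs from compound 2 by a group of 4 heavy atoms (2 carbon, 2 oxygen; no ring) in place of a group of 7 heavy atoms (6 carbon, 1 silicon; no ring), on a saturated chain carbon bound to a double-bonded ring carbon, with methoxymethoxy entering on a saturated chain carbon bound to a double-bonded ring carbon. Within the data shown here, one measured step bears on this place: a 1.1-fold lower number from compound 1 to compound 2 (0.04 log units; within the scatter). A group exchange there left the number within the scatter, so none beyond the scatter is expected now, and the expected change is a 1.0-fold higher number from compound 2 to compound 3 (0.02 log units; within the scatter). The estimate for compound 3 is 2900 nM, with an expected range of 1500 nM to 5500 nM.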

Compound 3, half-maximal inhibitory concentration: 2840 nM
Beside the measured number, compound 3's estimate is 1.0-fold (0.01 log units) above it; the range from low to high includes it.
By their numbers in this assay, from the lowest: compounds 2, 3 and 1 (each within the scatter of the next).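

In this assay, replacing the silicon-bearing group with methoxymethoxy gave a 1.0-fold higher number from compound 2 to compound 3 (0.01 log units; within the scatter) and so changed the number no more than the earlier exchange at this place had. Adding methoxy to the methoxy-bearing chain of compound 1 gave a 1.1-fold lower number from compound 1 to compound 3 (0.03 log units; within the scatter) as well, so a group with 2 hydrogen-bond acceptors and one with 0 read alike here. No supporting data explain this result. On these data alone, whether an amine, a carboxylic acid or a longer chain at this place would also leave the number within the scatter remains open.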